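Thioether-linked cyanopyrrolone series: cytotoxicity on MCF7 cells

The compounds below may be only part of what the source reports. "The series", "measured", "known", "first", "only" and "open" are said of these compounds alone.

Measured compounds:
compound 1 `N#CC1=C2C(=NC1=O)c1cccc3c(Sc4ccc(Br)cc4)ccc2c13`: 90 nM
compound 2 `N#CC1=C2C(=NC1=O)c1cccc3c(Sc4ccc(N)cc4)ccc2c13`: 12 nM

In a functional assay on MCF7 cells (Homo sapiens) for cytotoxicity, read by MTT assay, with a stated time of 24 h (a higher number here means a weaker inhibitor, a lower number a stronger inhibitor), compound 2 gives the lowest of the two numbers; compound 1 is the nearest, a 7.5-fold lower number from compound 1 to compound 2 (0.88 log units; beyond the scatter). Compound 3 `CCC(C)(C)c1ccc(Sc2ccc3c4c(cccc24)C2=NC(=O)C(C#N)=C23)cc1` is not yet measured; it differs from compound 2 by 1,1-dimethylpropyl in place of amino on an aromatic carbon. The only step on record at this position is from compound 1 to compound 2, where a halogen gave way to amino, with the size shown above. Removing the amino group again for a bulky alkyl is expected to reverse most of that gain, so a higher number is expected for compound 3, with the estimated step of an 8.3-fold higher number from compound 2 to compound 3 (0.92 log units; beyond the scatter). Compound 3 is estimated at 100 nM, range 25 nM to 400 nM.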

Compound 3, half-maximal inhibitory concentration: 21300 nM
Beside the measured number, compound 3's estimate is 210-fold (2.33 log units) below it; the measured number lies above the stated range.
By their numbers in this assay, from the lowest: compound 2; then compound 1; then compound 3.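

In this assay this position tolerates far less than the change from bromo to amino suggested: 1,1-dimethylpropyl in place of amino gives a 1800-fold higher number from compound 2 to compound 3 (3.25 log units; beyond the scatter) and 1,1-dimethylpropyl in place of bromo gives a 240-fold higher number from compound 1 to compound 3 (2.37 log units; beyond the scatter). The substituent here can therefore move the number over a much wider span than the first pair showed. Nothing on hand accounts for this loss. Still open, from the compounds shown here alone, is how a methyl, a hydroxyl or a dimethylamino group at this place would read, and so whether the loss follows alkyl groups generally or this branched chain alone.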